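Moving the branch point along the acid chain

This account rests on a few compounds, and the source may have more. Where it says the series, first, only, none or still open, it means among the compounds named here.

Measured so far:
compound 1 `O=C(O)CCC(=O)Nc1cccc(OCc2ccc3ccc(F)cc3n2)c1`: 200 nM
compound 2 `O=C(CC1(C(=O)O)CCCCC1)Nc1cccc(OCc2ccc3ccc(F)cc3n2)c1`: 7.3 nM

For the measured compounds named here, in a functional assay on ileum (Cavia porcellus) for antagonist activity at cysteinyl leukotriene receptor (Homo sapiens) (a lower number here means a stronger inhibitor, a higher number a weaker inhibitor), compound 2 gives the lowest of the two numbers, with compound 1 as its only neighbour; the step of a 27-fold lower number from compound 1 to compound 2 (1.44 log units; beyond the scatter) was large. Compound 3 `CCC(CC)(CC(=O)O)C(=O)Nc1cccc(OCc2ccc3ccc(F)cc3n2)c1` carries 1-(carboxymethyl)-1-ethylpropyl in place of (1-carboxycyclohexyl)methyl on a carbonyl carbon. Going by the values given here, only that one step bears on the change, and it rewards branching on the acid-bearing chain; compound 3 keeps a branch but shifts it, so some loss is expected. The expected step is a 2.7-fold higher number from compound 2 to compound 3 (0.44 log units; beyond the scatter). Compound 3 is expected to give 20 nM, between 5 nM and 80 nM.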

Compound 3, half-maximal inhibitory concentration: 140 nM
Compound 3: the middle estimate sits 7.0-fold (0.85 log units) below what was measured; the measured number lies above the stated range.
By their numbers in this assay, from the lowest: compound 2; then compounds 3 and 1 (each within the scatter of the next).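

A branch on the acid-bearing chain does not by itself bring the gain seen in compound 2: in this assay, 1-(carboxymethyl)-1-ethylpropyl in place of (1-carboxycyclohexyl)methyl gives a 19-fold higher number from compound 2 to compound 3 (1.28 log units; beyond the scatter) as the result of this change. The branched compound 3 also stands level with the 2-carboxyethyl chain of compound 1, with a 1.4-fold lower number from compound 1 to compound 3 (0.15 log units; within the scatter) between these two. Nothing measured here explains this loss.

The ring and the place of the branch change together in this step, and the compounds shown do not separate them. A 1-(carboxymethyl)cyclohexyl group, keeping the ring with the moved branch, would be the open comparison.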